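Halogen swap on the anilide ring of a quinoline acid

The source may report more compounds than this note shows. Statements on the series, on what has been measured and on what is new or still open speak of the compounds shown alone.

Of the compounds shown here, two have been measured in a physicochemical assay for lipophilicity, using the shake flask method, in phosphate buffer, measured as octanol-water partition, at pH 7.4; on this read-out higher numbers stand for higher lipophilicity and lower numbers for lower lipophilicity. Compound 1, `COc1cc(-c2cc(C(=O)O)c3ccccc3n2)ccc1OCC(=O)Nc1ccccc1`, gives 0.7. Compound 2, `COc1cc(-c2cc(C(=O)O)c3ccccc3n2)ccc1OCC(=O)Nc1ccccc1F`, gives 0.9. Among the measured compounds shown here, the single step between them, a number 0.20 log units higher from compound 1 to compound 2 (within the scatter), is fluoro in place of hydrogen on an aromatic carbon. Compound 2 thus stands highest of the two numbers, though its gap to compound 1 lies within the scatter, so no order between them can be read.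

Compound 3, `COc1cc(-c2cc(C(=O)O)c3ccccc3n2)ccc1OCC(=O)Nc1cccc(Cl)c1`, is the next candidate. It differs from compound 2 by 3-chlorophenyl in place of 2-fluorophenyl on an amide-type nitrogen. For the measured compounds named here, the only measured step that bears on this change is the one from compound 1 to compound 2, where adding a fluorine to the phenyl ring moved the value by an amount inside the scatter. Going by the values given here, no measured pair exchanges fluorine for chlorine, and no measured compound carries a chlorine at all, so the size of this step has no direct precedent here. Compound 3 is expected to come out somewhat higher in this assay than compound 2, by an estimated a number 0.50 log units higher from compound 2 to compound 3 (beyond the scatter). The estimate for compound 3 is 1.4, in a range from 1 to 1.9.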

Compound 3, distribution coefficient: 2.3
For compound 3 the middle estimate is 0.90 log units below the measured one; measured number outside the range, above it.
By their numbers in this assay, from the lowest: compounds 1 and 2 (each within the scatter of the next); then compound 3.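

On the phenyl ring carried by the amide-type nitrogen, this assay proves responsive to substitution, which the fluoro step alone had not shown: 3-chlorophenyl in place of 2-fluorophenyl gives a number 1.40 log units higher from compound 2 to compound 3 (beyond the scatter), and chloro in place of hydrogen gives a number 1.60 log units higher from compound 1 to compound 3 (beyond the scatter). Among the compounds shown here, compound 3 is therefore the first compound in this set to stand apart from the others beyond the scatter, with its steps to both compound 1 and compound 2 printed as large, while those two remain within the scatter of each other. Nothing available accounts for the size of these steps.

2-fluorophenyl and 3-chlorophenyl differ both in the halogen and in its place on the ring, so the compounds shown leave open how much of the step belongs to the chlorine itself and how much to where it sits. Also open, going by these compounds, is what a bromine, a methoxy group or an amine on this phenyl ring would give in this assay, and whether any of them would match the chloro compound.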